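A few compounds are considered here, and "the series" means these few. Any claim that something is new, unique, unknown or untested is made for them only; others in the source may bear on it.

Going by the values given here, compound 2, with the structure `CCCCn1cc(C(=O)Nc2ccc(C)c(S(=O)(=O)N3CCOCC3)c2)c(-c2ccc(C)cc2)n1`, stands at the upper end of the two numbers measured so far, though only by a margin that the step itself shows to be within the scatter. In an assay on HEK-293T cells for inhibition of Bile acid receptor (Homo sapiens), read by a beta-lactamase reporter, with a stated time of 16 h (a lower number here means a stronger inhibitor, a higher number a weaker inhibitor), compound 2 gives 11500 nM. Among the compounds with values here, its nearest neighbour is compound 1, `Cc1ccc(-c2nn(-c3cccc(Cl)c3)cc2C(=O)Nc2ccc(C)c(S(=O)(=O)N3CCOCC3)c2)cc1`, which in this assay gives 5910 nM; the step of a 1.9-fold higher number from compound 1 to compound 2 (0.29 log units; within the scatter) is the only measured step here, and it concerns the group on the same aromatic nitrogen. Compound 3, `Cc1ccc(-c2nn(CC3CC3)cc2C(=O)Nc2ccc(C)c(S(=O)(=O)N3CCOCC3)c2)cc1`, has not yet been measured. It differs from compound 2 by cyclopropyl in place of propyl on a saturated chain carbon bound to an aromatic nitrogen. Since swapping a 3-chlorophenyl group for butyl on that nitrogen stayed within the scatter, exchanging propyl for cyclopropyl, a group with the same count of carbon atoms, gives no reason to expect a change beyond the scatter in either direction. Compound 3 is therefore expected to show a 1.2-fold lower number from compound 2 to compound 3 (0.06 log units; within the scatter), an estimate of 10000 nM with a range from 4000 nM to 25000 nM.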

Compound 3, half-maximal inhibitory concentration: 849 nM
For compound 3 the middle estimate is 12-fold (1.07 log units) above the measured one; the measured number lies below the stated range.
By their numbers in this assay, from the lowest: compound 3; then compounds 1 and 2 (each within the scatter of the next).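

In this assay, the earlier step on this nitrogen stayed within the scatter, but cyclopropyl in place of propyl on the saturated chain carbon gives a 14-fold lower number from compound 2 to compound 3 (1.13 log units; beyond the scatter) even though three carbons leave and three enter, so the group here can matter strongly when only a ring is added. Cyclopropylmethyl in place of 3-chlorophenyl on the same nitrogen likewise gives a 7.0-fold lower number from compound 1 to compound 3 (0.84 log units; beyond the scatter) and makes compound 3 the strongest inhibitor of the three. Nothing available explains why this ring has such an effect. The compounds shown leave open whether cyclobutyl or cyclohexyl on the same chain carbon would do as well as cyclopropyl. They also leave open how a branched isopropyl group, or a chain ending in an amine, would behave on this nitrogen.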